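Changing the acyl group on the piperidine nitrogen

The source may report more compounds than this note shows. Statements on the series, on what has been measured and on what is new or still open speak of the compounds shown alone.

Compound 1: `Cc1nc(S(C)(=O)=O)ccc1Oc1ncnc(OC2CCN(C(=O)O[C@@H](C)CF)CC2)c1F` — 1680 nM in a functional assay on isolated protein for inhibition of Glucose-dependent insulinotropic receptor (Rattus norvegicus), read by HTRF and cAMP accumulation; a lower number here means that less compound is needed, a higher number that more compound is needed for the effect
Compound 2: `Cc1nc(S(C)(=O)=O)ccc1Oc1ncnc(OC2CCN(C(=O)SC3(C)CC3)CC2)c1F` — 166 nM in this assay

Of the compounds shown here, two sharing one core have been measured so far. Among the compounds with values here, compound 2 stands at the lower of the two numbers, and the only neighbour it has, compound 1, sits a long way off: a 10-fold lower number from compound 1 to compound 2 (1.01 log units; beyond the scatter). That single step is the whole of what is known about the substituent on the carbonyl carbon, and it shows that this position can move the readout by a large amount.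

Compound 3, `Cc1nc(S(C)(=O)=O)ccc1Oc1ncnc(OC2CCN(C(=O)C(F)(F)F)CC2)c1F`, carries a different group at the same place: a group of 4 heavy atoms (1 carbon, 3 fluorine; no ring) in place of a group of 5 heavy atoms (4 carbon, 1 sulfur; one three-membered non-aromatic ring of carbon only), on a carbonyl carbon. Within the data shown here, no measured pair mirrors this exchange; the step from compound 1 to compound 2 only says that the carbonyl substituent is not neutral. Since the group that enters is small and unlike either of the measured ones, a move away from the low number of compound 2 is expected, of uncertain size: a 9.0-fold higher number from compound 2 to compound 3 (0.96 log units; beyond the scatter). For compound 3 the estimated value in this assay is 1500 nM, within a range of 400 nM to 6000 nM.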

Compound 3, half-maximal effective concentration: 880 nM
The estimate for compound 3 lay 1.7-fold (0.23 log units) above the measured number, and the stated range covers the measured number.
By their numbers in this assay, from the lowest: compound 2; then compounds 3 and 1 (each within the scatter of the next).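

Trifluoromethyl on the carbonyl carbon does not hold the low number of compound 2: in this assay the exchange gives a 5.3-fold higher number from compound 2 to compound 3 (0.72 log units; beyond the scatter), a smaller move than the one that first showed this position to matter. Compound 3 also lands level with compound 1, with a 1.9-fold lower number from compound 1 to compound 3 (0.28 log units; within the scatter), so two groups with no ring and quite different atoms cannot be told apart here, and among these three compounds the low number belongs only to the group holding sulfur and the three-membered ring. No measurement on hand explains this difference between the groups.

The three compounds do not show whether the sulfur or the three-membered ring carries the gain, since the two change together; the same ring joined through an oxygen, or a sulfur bearing a plain ethyl chain, would separate them. Going by these compounds, how an amine or a longer carbon chain on the carbonyl carbon would read in this assay also remains open. Compound 2 gives 166 nM, and whether any group can go further down is not known either.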